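Series notes: aryl-amide hexanoic acids, cytotoxicity on HEK293 cells

The source may hold more compounds than are shown below. What is called first, only, known or untested is meant among the compounds shown, and "the series" means these compounds.

Measured compounds:
- compound 1 `CC(C)Oc1cccc(-c2ccc(C(=O)N(Cc3cccc(OCCCCCC(=O)O)c3)C(C)C)cc2)c1` gives in an ADME assay on HEK293 cells (Homo sapiens) for cytotoxicity, read by CellTiter-Glo and resazurin assay, with a stated time of 72 h (on this read-out higher numbers stand for an effect only at larger amounts of compound and lower numbers for an effect already at smaller amounts), only a limit, > 26000 nM.
- compound 2 `CCOc1cccc(-c2ccc(C(=O)N(Cc3cccc(OCCCCCC(=O)O)c3)C(C)C)cc2)c1` gives in this assay only a limit, > 20800 nM.

Compound 2 stands at a limit of this assay rather than at a number. Among the measured compounds shown here, the only step within the measured pair, a step that the two limits leave unreadable from compound 1 to compound 2, cannot be read, since both ends rest on limits, namely the limit of > 20800 nM in this assay, at which 1 of the 2 values shown sits, and (the limit of > 26000 nM in this assay, at which 1 of the 2 values shown sits); the two compounds therefore cannot be ordered against each other on this read-out.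

The next compound is compound 3 `COc1ccc(F)c(-c2ccc(C(=O)N(Cc3cccc(OCCCCCC(=O)O)c3)C(C)C)cc2)c1`. The change from compound 2 is 2-fluoro-5-methoxyphenyl in place of 3-ethoxyphenyl on an aromatic carbon. For the measured compounds named here, neither of the two limits bears directly on this exchange of the aryl substituent; the one measured step is not readable and so gives no size to carry over. What the pair does show is that both measured compounds sit at a limit in this assay, and nothing in the data points to compound 3 behaving otherwise.

The expectation for compound 3 in this assay is therefore a value of about 25000 nM, in the range 10000 nM to 80000 nM, most probably reported again as a limit; the expected step that the limit leaves unreadable from compound 2 to compound 3 is none beyond the scatter.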

Compound 3, half-maximal effective concentration: > 26000 nM
Compound 3 gave a limit, no number; the forecaster's own chance of this, stated with the estimate: 80%; middle value at least 1.0-fold (0.01 log units) away from the limit.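

Compound 3 gives > 26000 nM in this assay and this is only a limit. Compound 1 and compound 2 also rest on limits, so neither step to compound 3 can be read. Left open is whether the aryl exchanges shift the read-out in this assay at all, and at what concentration any of the three compounds reaches a half-maximal effect.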